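Nitro for Methoxy on a Second Core in HL-60 Cells

A few compounds are considered here, and "the series" means these few. Any claim that something is new, unique, unknown or untested is made for them only; others in the source may bear on it.

Measured compounds:
compound 1 `COc1ccc(S(=O)(=O)Oc2ccccc2/C=C(\C#N)C(=O)Nc2nnc(Cc3cccc4ccccc34)s2)cc1` — 98% in a functional assay on HL-60 cells (Homo sapiens) for inhibition, read by CCK-8 assay, with a stated time of 48 h, tested at 20 uM; a higher number here means more inhibition of growth at the concentration tested, a lower number less inhibition of growth
compound 2 `N#C/C(=C\c1ccccc1OS(=O)(=O)c1ccc([N+](=O)[O-])cc1)C(=O)Nc1nnc(Cc2cccc3ccccc23)s1` — 18%
compound 3 `COc1ccc(S(=O)(=O)Oc2ccccc2/C=C(\C#N)C(=O)Nc2nnc(Cc3cccc(F)c3)s2)cc1` — 100%

Compound 1 and compound 3 share most of their structure; their cores differ by 3-fluorophenyl in place of naphthalen-1-yl on a saturated chain carbon bound to an aromatic carbon, a change that gave a number 2 percentage points higher from compound 1 to compound 3 (within the scatter). Compound 2 arises from compound 1 by nitro in place of methoxy on an aromatic carbon, and this step gave a number 80 percentage points lower from compound 1 to compound 2 (beyond the scatter).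

Compound 4 `N#C/C(=C\c1ccccc1OS(=O)(=O)c1ccc([N+](=O)[O-])cc1)C(=O)Nc1nnc(Cc2cccc(F)c2)s1` has not yet been measured in this assay. It arises from compound 3 by nitro in place of methoxy on an aromatic carbon, the same change as that from compound 1 to compound 2, made on the core of compound 3 rather than the core of compound 1. Because a number 80 percentage points lower from compound 1 to compound 2 (beyond the scatter) was large, and because the two cores gave nearly the same number in a number 2 percentage points higher from compound 1 to compound 3 (within the scatter), a step of similar size is expected here: a number 80 percentage points lower from compound 3 to compound 4 (beyond the scatter). Compound 4 is therefore estimated at 20%, with a range expected from 5% to 50%.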

Compound 4, percent growth inhibition at one concentration: 18%
The estimate for compound 4 lay 2 percentage points above the measured number, within the range that was stated.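

In this assay, nitro in place of methoxy gave a number 82 percentage points lower from compound 3 to compound 4 (beyond the scatter), a step that matches the one seen on the core of compound 1: the same change on two cores in this assay, a number 80 percentage points lower (beyond the scatter) from compound 1 to compound 2 and a number 82 percentage points lower (beyond the scatter) from compound 3 to compound 4, 2 percentage points apart, within the scatter of two such steps. Exchanging naphthalen-1-yl for 3-fluorophenyl gave no change at the digits printed from compound 2 to compound 4 (within the scatter), so that exchange made no difference beyond the scatter with either the methoxy or the nitro group in place: the same change on two cores in this assay, a number 2 percentage points higher (within the scatter) from compound 1 to compound 3 and no change at the digits printed (within the scatter) from compound 2 to compound 4, 2 percentage points apart, within the scatter of two such steps. Together these show that the change carried over between these two cores with a step of the same size, but they do not show that it would carry over to any other core, nor do they explain the loss of growth inhibition.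

On these data alone, it remains open how an amine or a carboxylic acid in place of methoxy on that aromatic carbon would read. Also open, as far as these compounds go, is whether the step would persist with a longer chain in place of 3-fluorophenyl.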